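The source may hold more compounds than are shown below. What is called first, only, known or untested is meant among the compounds shown, and "the series" means these compounds.

Measured so far, all in a functional assay on the whole organism (strain Wistar) for inhibition, with Rattus norvegicus as the target, read by paw edema, with stated times of 60 min and 3 h, at a dose of 100 mg/kg by the oral route; a lower number here means less inhibition, a higher number more inhibition at the dose given (going by the name of the read-out):
Compound 1, `CCCCCNC(=O)CC1CCc2cc(OC)c(OC)cc21`, gives 37.7%.
Compound 2, `CCCCCCNC(=O)CC1CCc2cc(OC)c(OC)cc21`, gives 44.6%.
Compound 3, `COc1cc2c(cc1OC)C(CC(=O)NC1CCCCC1)CC2`, gives 49.3%.

Compound 3 has the highest of the three numbers. Its nearest neighbour is compound 2, and that gap, a number 4.7 percentage points higher from compound 2 to compound 3 (within the scatter), lies within the scatter, so the two cannot be ranked against each other. Against compound 1 the gap is larger, a number 11.6 percentage points higher from compound 1 to compound 3 (beyond the scatter), a modest step beyond the scatter. The remaining step, a number 6.9 percentage points higher from compound 1 to compound 2 (within the scatter), is within the scatter.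

Compound 4, `COc1cc2c(cc1OC)C(CC(=O)NCCO)CC2`, has not yet been measured. It differs from compound 3 in one place: 2-hydroxyethyl in place of cyclohexyl on an amide-type nitrogen. For the measured compounds named here, the steps that bear on this are the two in which cyclohexyl replaced a chain on the amide-type nitrogen, a number 11.6 percentage points higher from compound 1 to compound 3 (beyond the scatter) and a number 4.7 percentage points higher from compound 2 to compound 3 (within the scatter). Going by the values given here, both point the same way, one modestly beyond the scatter and one within it, but no measured step involves 2-hydroxyethyl, so they give only a loose guide. In the measured pairs, the absence of cyclohexyl went with a somewhat lower number, and a small step downward is therefore expected in this assay, possibly no larger than the scatter. For compound 4 the estimate is 36%, within the range 20% to 50%, an expected step of a number 13.3 percentage points lower from compound 3 to compound 4 (beyond the scatter).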

Compound 4, a percentage reported as inhibition, in the whole organism at one dose (the size of the read-out at that dose, not a potency): 12.3%
Compound 4: the middle estimate sits 23.7 percentage points above what was measured; measured number outside the range, below it.
By their numbers in this assay, from the lowest: compound 4; then compounds 1, 2 and 3 (each within the scatter of the next, the first and the last beyond it).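

In this assay, for the compounds shown here, the group on the amide-type nitrogen turns out to matter far more than the earlier compounds suggested: replacing cyclohexyl with 2-hydroxyethyl gives a number 37 percentage points lower from compound 3 to compound 4 (beyond the scatter) and counts as a large step, whereas the earlier changes at this position were modest or within the scatter. The fall is not tied to losing a ring, since measuring against the open chains gives a number 32.3 percentage points lower from compound 2 to compound 4 (beyond the scatter) for the hexyl compound and a number 25.4 percentage points lower from compound 1 to compound 4 (beyond the scatter) for the pentyl compound, which places compound 4 lowest of the four, beyond the scatter from each of the others. No measurement shown here accounts for this fall.

Compound 4 changes two things at once, bringing in a hydroxy group and a shorter chain, so the effect of each remains unseparated; a plain ethyl or butyl chain, a 2-methoxyethyl group, or a 4-hydroxycyclohexyl group would help pull them apart. Also open, from the compounds shown here alone, is whether an amine or a carboxylic acid at the end of the chain would give a number as low as that of compound 4.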